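This account rests on a few compounds, and the source may have more. Where it says the series, first, only, none or still open, it means among the compounds named here.

In a functional assay on L1210 cells (Mus musculus) for antiproliferative activity (a lower number here means a stronger inhibitor, a higher number a weaker inhibitor), compound 1 (`COc1ccc(-c2cc(N)c(C(=O)c3cc(OC)c(OC)c(OC)c3)s2)cc1OC`) gives 40 nM, compound 2 (`COc1cc(C(=O)c2sc(-c3ccc(I)cc3)cc2N)cc(OC)c1OC`) gives 400 nM and compound 3 (`COc1cc(C(=O)c2sc(-c3ccccc3Cl)cc2N)cc(OC)c1OC`) gives 20 nM. Compound 3 thus sits at the low end alongside compound 1, with a 2.0-fold lower number from compound 1 to compound 3 (0.30 log units; within the scatter), while a 20-fold lower number from compound 2 to compound 3 (1.30 log units; beyond the scatter). Compound 4 (`COc1cc(C(=O)c2sc(-c3ccsc3)cc2N)cc(OC)c1OC`) has thiophen-3-yl in place of 2-chlorophenyl on an aromatic carbon. For the measured compounds named here, no measured compound carries this group, so only the other swaps at this place can guide the estimate. Besides the two steps above, a 10-fold higher number from compound 1 to compound 2 (1.00 log units; beyond the scatter), so such swaps can range from no clear change to a large one. A moderate rise is therefore expected in this assay, a 5.0-fold higher number from compound 3 to compound 4 (0.70 log units; beyond the scatter). Compound 4 is estimated at 100 nM, with an expected range of 20 nM to 500 nM.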

Compound 4, half-maximal inhibitory concentration: 12 nM
Estimate against measurement, compound 4: 8.3-fold (0.92 log units) above; the whole stated range lies above it.
By their numbers in this assay, from the lowest: compounds 4, 3 and 1 (each within the scatter of the next, the first and the last beyond it); then compound 2.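

In this assay, replacing the six-membered 2-chlorophenyl ring with the five-membered thiophen-3-yl ring gives a 1.7-fold lower number from compound 3 to compound 4 (0.22 log units; within the scatter) and so no clear change, which shows that this place does not need a six-membered ring of carbon only. Thiophen-3-yl also compares well with the other two groups, with a 3.3-fold lower number from compound 1 to compound 4 (0.52 log units; beyond the scatter) and a 33-fold lower number from compound 2 to compound 4 (1.52 log units; beyond the scatter) as the steps. Nothing available explains these differences. On these data alone, whether this place needs an aromatic ring at all stays open. A cyclohexyl ring or a morpholine ring here would test that.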